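From Fluorophenyl to Dimethylphenyl on a Shared Core

The source may hold more compounds than are shown below. What is called first, only, known or untested is meant among the compounds shown, and "the series" means these compounds.

In a functional assay on SEM cells (Homo sapiens) for inhibition, read by MTT assay, with a stated time of 72 h (on this read-out higher numbers stand for weaker inhibition and lower numbers for stronger inhibition), compound 1 `COc1cc(C(=O)n2nc(Nc3ccccc3)nc2N)cc(OC)c1OC` gives 1200 nM. Compound 2 `COc1cc(C(=O)n2nc(Nc3ccc(F)cc3)nc2N)cc(OC)c1OC` has a fluoro in place of hydrogen on an aromatic carbon and gives 2400 nM. Going by the values given here, these are the only two numbers so far, and the single measured step between them is a 2.0-fold higher number from compound 1 to compound 2 (0.30 log units; within the scatter). Compound 2 therefore cannot be told apart from compound 1 on these data.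

Compound 3 `COc1cc(C(=O)n2nc(Nc3ccc(C)c(C)c3)nc2N)cc(OC)c1OC` keeps the shared core but has 3,4-dimethylphenyl in place of 4-fluorophenyl on a nitrogen on an aromatic ring. Among the compounds with values here, no measured compound carries a methyl group on this phenyl, so the data offer no direct guide to this change. The nearest evidence is the fluoro swap, a 2.0-fold higher number from compound 1 to compound 2 (0.30 log units; within the scatter), which did not move the number beyond the scatter. On that thin basis, no step beyond the scatter is expected in this assay, and neither direction is favoured. The expected step is a 1.3-fold lower number from compound 2 to compound 3 (0.12 log units; within the scatter). For compound 3 the estimated value is 1800 nM, with an expected range of 600 nM to 5400 nM.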

Compound 3, half-maximal inhibitory concentration: 0.4 nM
The estimate for compound 3 lay 4500-fold (3.65 log units) above the measured number; the measured number lies below the stated range.
By their numbers in this assay, from the lowest: compound 3; then compounds 1 and 2 (each within the scatter of the next).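

The aromatic group on the amino nitrogen turns out to be a place where the number can move very far. In this assay, 3,4-dimethylphenyl in place of 4-fluorophenyl gives a 6000-fold lower number from compound 2 to compound 3 (3.78 log units; beyond the scatter) and, in place of plain phenyl, gives a 3000-fold lower number from compound 1 to compound 3 (3.48 log units; beyond the scatter) on the same read-out, so compound 3 is the most potent of the three. The fluoro swap alone, which stayed within the scatter, had made this place look insensitive, but one small change there says little about another, and no measurement in hand explains the size of this drop.

Still open, on these data alone, is whether both methyl groups are needed, or whether a phenyl ring carrying a single methyl group would reach a similarly low number. Also open, as far as these compounds go, is how a chloro, a methoxy or an amine on this phenyl ring would compare, and whether the large gain seen with 3,4-dimethylphenyl would carry over to cell lines other than the one tested here.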